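The source may report more compounds than this note shows. Statements on the series, on what has been measured and on what is new or still open speak of the compounds shown alone.

Three compounds share one core and differ only in one group on an aromatic carbon. Compound 1 `CC(=O)Nc1cccc(-c2ccc(C(=O)N(Cc3cccc(OCCCCCC(=O)O)c3)C(C)C)cc2)c1` carries acetamido there. In an ADME assay on Raji cells (Homo sapiens) for cytotoxicity, read by CellTiter-Glo and resazurin assay, with a stated time of 72 h (a lower number here means that less compound is needed, a higher number that more compound is needed for the effect), compound 1 gives > 26000 nM, which is a limit of the assay rather than a number. Compound 2 `CC(C)COc1cccc(-c2ccc(C(=O)N(Cc3cccc(OCCCCCC(=O)O)c3)C(C)C)cc2)c1` carries isobutoxy instead. In this assay compound 2 likewise reaches only the limit > 26000 nM. Compound 3 `CC(C)N(Cc1cccc(OCCCCCC(=O)O)c1)C(=O)c1ccc(-c2cccc(C(F)(F)F)c2)cc1` carries trifluoromethyl, and compound 3 also sits at the limit > 26000 nM. Because the limit of > 26000 nM in this assay, at which 3 of the 3 values shown sit, holds all three values, the steps a step that the two limits leave unreadable from compound 1 to compound 2, a step that the two limits leave unreadable from compound 1 to compound 3 and a step that the two limits leave unreadable from compound 2 to compound 3 cannot be read in size or direction. Compound 4 `CC(C)N(Cc1cccc(OCCCCCC(=O)O)c1)C(=O)c1ccc(-c2ccc(Cl)c(Cl)c2)cc1` is not yet measured; it differs from compound 2 by 3,4-dichlorophenyl in place of 3-(isobutoxy)phenyl on an aromatic carbon. Among the compounds with values here, no measured step tells how this change acts, so the only guide is that every neighbour so far lies at the limit. The step of a number no higher from compound 2 to compound 4 (the limit leaves the size open) is therefore expected to be one that cannot be read. Compound 4 is expected to give about 26000 nM in this assay, within a range from 10000 nM to 60000 nM.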

Compound 4, half-maximal effective concentration: > 26000 nM
Compound 4: no number, only a limit; the forecaster's own chance of this, stated with the estimate: 80%; the middle value sits exactly at the limit.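

Within the data shown here, no step from compound 1, compound 2 or compound 3 to compound 4 can be read in size or direction, because all four share one assay limit: the limit of > 26000 nM in this assay, at which 4 of the 4 values shown sit. The compounds shown leave open how much of any of them this assay would need for the effect, and whether changing this group alters that amount.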